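The compounds below may be only part of what the source reports. "The series", "measured", "known", "first", "only" and "open" are said of these compounds alone.

Compound 1, `Nc1nc2ccc(-c3cnc(Cl)c(NS(=O)(=O)c4ccc(F)cc4)c3)cc2[nH]1`: in an assay on U-87MG ATCC cells for inhibition of RAC-alpha serine/threonine-protein kinase (Homo sapiens), read by AlphaScreen, with a stated time of 2 h (a lower number here means a stronger inhibitor, a higher number a weaker inhibitor), compound 1 gives > 12000 nM, which is a limit of the assay and not a number.
Compound 2, `Nc1nc2ccc(-c3cnc(Cl)c(NS(=O)(=O)c4ccc(F)cc4)c3)cc2s1`: compound 2 gives 44 nM.
Compound 3, `Nc1cn2cc(-c3cnc(Cl)c(NS(=O)(=O)c4ccc(F)cc4)c3)ccc2n1`: compound 3 gives > 12000 nM, again only a limit of the assay.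

Among the compounds with values here, compound 3 thus stands at the weak end of what has been measured, sharing its limit with compound 1 (the limit of > 12000 nM in this assay, at which 2 of the 3 values shown sit); compound 2 is the only one with a measured number. Compound 4, `O=S(=O)(Nc1cc(-c2ccc3nccn3c2)cnc1Cl)c1ccc(F)cc1`, is not yet measured. It differs from compound 3 in one place: hydrogen in place of amino on an aromatic carbon. Within the data shown here, no step between measured compounds is available to set the size of this change. Compound 3 already sits at the limit, so compound 4 is expected to stay weak, with an estimated step that the limit leaves unreadable from compound 3 to compound 4, that is, nothing beyond the scatter. The estimate for compound 4 is 20000 nM, between 5000 nM and 80000 nM, most likely reported as a limit.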

Compound 4, half-maximal inhibitory concentration: 574 nM
Beside the measured number, compound 4's estimate is 35-fold (1.54 log units) above it; the measured number lies below the stated range.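

On the aromatic carbon of the five-membered ring, hydrogen in place of amino gives an at least 20-fold lower number from compound 3 to compound 4 (1.32 log units; beyond the scatter). The amino group is therefore not needed for measurable inhibition on this core, and here its absence goes with the stronger compound. The size of this step is only a bound, because compound 3 gives a limit of the assay and not a number: the limit of > 12000 nM in this assay, at which 2 of the 4 values shown sit.

Why the amino group costs so much stays open. So does whether a methyl group or a hydroxyl group on this carbon would behave like hydrogen or like amino.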